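The source may report more compounds than this note shows. Statements on the series, on what has been measured and on what is new or still open speak of the compounds shown alone.

Measured so far in a functional assay for inhibition of nuclear factor NF-kappa-B complex (Homo sapiens); a higher number here means a weaker inhibitor, a lower number a stronger inhibitor:

compound 1 `COc1ccc2c(c1)OC(c1cc(OC)c(OC)c(OC)c1)C(C(=O)N1CCCCC1)=C2` — > 50000 nM, a limit of this assay, not a number.
compound 2 `CCNC(=O)C1=Cc2ccc(OC)cc2OC1c1cc(OC)c(OC)c(OC)c1` — > 50000 nM, likewise a limit of this assay.

Compound 2 therefore stands at the limit, with no number of its own; both values shown sit there, as the limit of > 50000 nM in this assay, at which 2 of the 2 values shown sit, records. Among the measured compounds shown here, the single measured step, a step that the two limits leave unreadable from compound 1 to compound 2, is left unreadable by the two limits.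

Compound 3 `COc1ccc2c(c1)OC(c1cc(OC)c(OC)c(OC)c1)C(C(C)=O)=C2` differs from compound 2 by methyl in place of ethylamino on a carbonyl carbon. No measured step bears on this change: the only step shown, from compound 1 to compound 2, is unreadable, and it concerns a different exchange on the same carbonyl carbon. With compound 2 at the limit and no readable step, the working expectation is that compound 3 also comes back as a limit, giving no readable step in this assay.

Compound 3 is estimated at 70000 nM, with a range from 20000 nM to 300000 nM. The estimated step from compound 2 to compound 3 is a step that the limit leaves unreadable from compound 2 to compound 3, most likely again unreadable.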

Compound 3, half-maximal inhibitory concentration: 14100 nM
Beside the measured number, compound 3's estimate is 5.0-fold (0.70 log units) above it, and the stated range ends above it.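

Replacing the group on this carbonyl carbon with methyl brings a readable number in this assay: methyl in place of ethylamino gives an at least 3.5-fold lower number from compound 2 to compound 3 (0.54 log units; beyond the scatter), and methyl in place of piperidin-1-yl gives an at least 3.5-fold lower number from compound 1 to compound 3 (0.54 log units; beyond the scatter). With the rest of the structure unchanged, the group on this carbonyl carbon therefore matters, which the unreadable step between the two amides could not show. Both steps give only a minimum size, because compound 1 and compound 2 stand at a limit: the limit of > 50000 nM in this assay, at which 2 of the 3 values shown sit.

Whether methyl is the best group here remains open, as the compounds shown include no longer chain such as propyl and no hydroxyl giving a carboxylic acid on this carbonyl carbon. On these data alone, how the two amides rank against each other also stays unknown.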